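Swapping Ethyl for Acetyl on a Ring Nitrogen

The source may hold more compounds than are shown below. What is called first, only, known or untested is meant among the compounds shown, and "the series" means these compounds.

In a functional assay on HCT-116 cells (Homo sapiens) for inhibition, read by CCK-8 assay, with a stated time of 48 h (on this read-out higher numbers stand for weaker inhibition and lower numbers for stronger inhibition), compound 1 `COc1ccc(CN(C(=O)CSC(=S)N2CCN(C(=O)OC(C)(C)C)CC2)c2cc(OC)c(OC)c(OC)c2)cc1O` gives 128 nM. Within the data shown here, compound 2 `CCN1CCN(C(=S)SCC(=O)N(Cc2ccc(OC)c(O)c2)c2cc(OC)c(OC)c(OC)c2)CC1` gives 530 nM, the higher of the two numbers so far, and so the weaker inhibition.

Among the measured compounds shown here, the only measured step is a 4.1-fold higher number from compound 1 to compound 2 (0.62 log units; beyond the scatter), with ethyl in place of tert-butoxycarbonyl on an amine nitrogen in a ring. Compound 3 `COc1ccc(CN(C(=O)CSC(=S)N2CCN(C(C)=O)CC2)c2cc(OC)c(OC)c(OC)c2)cc1O` changes the group at that same spot, with acetyl in place of ethyl on an amine nitrogen in a ring.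

One step is a thin guide, but it is the only one that bears on this change. Acetyl resembles tert-butoxycarbonyl in holding a carbonyl, which ethyl lacks, yet the two groups are not the same. Compound 3 is therefore expected to regain part of the gap to compound 1 at 128 nM, though perhaps not all of it.

The expected change is a 2.2-fold lower number from compound 2 to compound 3 (0.34 log units; beyond the scatter), a modest move towards stronger inhibition. Compound 3 is estimated at 240 nM, with an expected range of 90 nM to 600 nM.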

Compound 3, half-maximal inhibitory concentration: 780 nM
Compound 3: middle estimate off by 3.3-fold (0.51 log units), on the low side, and the stated range ends below it.
By their numbers in this assay, from the lowest: compound 1; then compounds 2 and 3 (each within the scatter of the next).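

In this assay, the step of a 1.5-fold higher number from compound 2 to compound 3 (0.17 log units; within the scatter) leaves acetyl and ethyl on this ring nitrogen with no readable difference, so adding a carbonyl here does not by itself recover the lower number of compound 1. The other step, a 6.1-fold higher number from compound 1 to compound 3 (0.78 log units; beyond the scatter), keeps that carbonyl and changes only what it carries, with methyl in place of tert-butoxy, which shows that the lower number of compound 1 goes with the whole tert-butoxycarbonyl group and not with the carbonyl alone. The data shown give no measured account of why these groups differ in this way.

On these data alone, it remains open which part of tert-butoxycarbonyl matters: methoxycarbonyl would keep the oxygen on the carbonyl while carrying only a methyl, and pivaloyl would keep the branched carbons without that oxygen. A bare ring amine, with only a hydrogen on this nitrogen, and a benzyl group at the same spot would also show whether compound 2 and compound 3 mark a general level for this position or only for these two groups.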